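The source may report more compounds than this note shows. Statements on the series, on what has been measured and on what is new or still open speak of the compounds shown alone.

In a functional assay (plasma) for inhibition, with Homo sapiens as the target (on this read-out lower numbers stand for stronger inhibition and higher numbers for weaker inhibition), compound 1 `O=C(O)CCC/C=C\C[C@@H]1[C@@H](NS(=O)(=O)c2ccc(F)cc2)CC[C@@H]1O` gives 640 nM, the middle of three values. Compound 2 `O=C(O)CCC/C=C\C[C@@H]1[C@@H](NS(=O)(=O)c2ccc(Cl)cc2)CC[C@@H]1O` gives 190 nM, and compound 3 `O=C(O)CC/C=C\C[C@@H]1[C@@H](NS(=O)(=O)c2ccc(F)cc2)CC[C@@H]1O` gives 1600 nM. Compound 4 `O=C(O)CCC/C=C\C[C@@H]1[C@H](O)CC[C@H]1NS(=O)(=O)c1ccc(F)cc1` departs from this pattern: the two compounds have the same atoms and bonds and differ only in configuration as drawn: 3 of 4 stereo elements differ; a stereocentre at a saturated ring carbon is drawn R in compound 1 and S in compound 4; a stereocentre at a saturated ring carbon is drawn S in compound 1 and R in compound 4; a stereocentre at a saturated ring carbon is drawn S in compound 1 and R in compound 4. Chloro in place of fluoro gave a 3.4-fold lower number from compound 1 to compound 2 (0.53 log units; beyond the scatter), and carboxy in place of carboxymethyl gave a 2.5-fold higher number from compound 1 to compound 3 (0.40 log units; beyond the scatter). Within the data shown here, neither measured step alters configuration, so both serve only as a scale of size, and the data hold no direct precedent for this change. With three ring stereocentres redrawn, a larger step than either is expected, towards weaker inhibition in this assay. The expected change is a 6.3-fold higher number from compound 1 to compound 4 (0.80 log units; beyond the scatter). For compound 4 the estimated value is 4000 nM, with an expected range of 700 nM to 20000 nM.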

Compound 4, half-maximal inhibitory concentration: 6000 nM
Estimate against measurement, compound 4: 1.5-fold (0.18 log units) below; the range from low to high includes it.
By their numbers in this assay, from the lowest: compound 2; then compound 1; then compound 3; then compound 4.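

In this assay, configuration at the ring stereocentres alone gives a 9.4-fold higher number from compound 1 to compound 4 (0.97 log units; beyond the scatter), with no atom or bond altered. This step is larger than those from the chloro and chain changes, so the drawn configuration of compound 1 matters at least as much here as either substituent edit: the fact that compounds 1 and 4 differ only in the configuration as drawn

On these data alone, the share of each of the three redrawn stereocentres remains open, as does whether the chloro and chain steps carry over to the configuration of compound 4. As far as these compounds go, a bromo group on the aromatic carbon or a longer chain ending in the carboxylic acid also remains open.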